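The source may report more compounds than this note shows. Statements on the series, on what has been measured and on what is new or still open speak of the compounds shown alone.

Measured in an ADME assay on WI-38 cells (Homo sapiens) for cytotoxicity, read by MTT assay, with a stated time of 72 h; on this read-out lower numbers stand for stronger inhibition and higher numbers for weaker inhibition:
compound 1 `CN(C)CCn1cnnc1-c1cc(Oc2ccc(NC(=O)N/N=C/c3ccc(Cl)cc3Cl)cc2F)ccn1`, 4760 nM;
compound 2 `COc1ccc(/C=N/NC(=O)Nc2ccc(Oc3ccnc(-c4nncn4CCN(C)C)c3)c(F)c2)c(OC)c1`, 6630 nM;
compound 3 `CN(C)CCn1cnnc1-c1cc(Oc2ccc(NC(=O)N/N=C/c3ccccc3O[N+](=O)[O-])cc2F)ccn1`, 6860 nM.

Compound 3 does not stand apart from compound 1 or compound 2; all three numbers lie within the scatter of one another. Compound 4 `CN(C)CCn1cnnc1-c1cc(Oc2ccc(NC(=O)N/N=C/c3ccc(F)cc3)cc2F)ccn1` differs from compound 3 in one place: 4-fluorophenyl in place of 2-(nitrooxy)phenyl on a carbon with a double bond to nitrogen. The steps that touch the same place are a 1.4-fold higher number from compound 1 to compound 3 (0.16 log units; within the scatter), a 1.0-fold higher number from compound 2 to compound 3 (0.01 log units; within the scatter) and a 1.4-fold higher number from compound 1 to compound 2 (0.14 log units; within the scatter); none of them went beyond the scatter, so changing the aryl group on the carbon with a double bond to nitrogen has so far left this assay flat. For compound 4 no step beyond the scatter is therefore expected, a 1.1-fold lower number from compound 3 to compound 4 (0.06 log units; within the scatter). The estimate for compound 4 in this assay is 6000 nM, with a range from 3000 nM to 12000 nM.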

Compound 4, half-maximal inhibitory concentration: 3980 nM
For compound 4 the middle estimate is 1.5-fold (0.18 log units) above the measured one, and the stated range covers the measured number.
By their numbers in this assay, from the lowest: compounds 4, 1, 2 and 3 (each within the scatter of the next).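

Within this assay the 4-fluorophenyl group on the carbon with a double bond to nitrogen stays within the scatter of all three earlier aryl groups (a 1.7-fold lower number from compound 3 to compound 4 (0.24 log units; within the scatter)) (a 1.7-fold lower number from compound 2 to compound 4 (0.22 log units; within the scatter)) (a 1.2-fold lower number from compound 1 to compound 4 (0.08 log units; within the scatter)). The flat picture at this position now also covers a group with fewer heavy atoms and fewer hydrogen-bond acceptors than 2-(nitrooxy)phenyl. No measurement offered here explains this flatness.

Still open, going by these compounds, is whether an aryl ring carrying an amine or a carboxylic acid would move the number beyond the scatter. The same holds for a straight alkyl chain in place of the aryl group.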